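The compounds below may be only part of what the source reports. "The series", "measured", "known", "first", "only" and "open" are said of these compounds alone.

Compound 1, `O=C(COc1ccc(C(=O)/C=C/c2ccc(Cl)cc2Cl)cc1)N[C@H]1CCOC1=O`, and compound 2, `O=C(COc1ccc(C(=O)/C=C/c2ccccc2Cl)cc1)N[C@H]1CCOC1=O`, were both tested in a functional assay on DU-145 cells (Homo sapiens) for antiproliferative activity, read by MTT assay, with a stated time of 72 h; on this read-out higher numbers stand for weaker inhibition and lower numbers for stronger inhibition. In this assay compound 1 gives 8610 nM, while compound 2 gives 3240 nM; the change between them is hydrogen in place of chloro on an aromatic carbon, and it brought a 2.7-fold lower number from compound 1 to compound 2 (0.42 log units; beyond the scatter). Compound 3, `O=C(CNc1cccc(Cl)c1)N[C@H]1CCOC1=O`, is built on a different core, and the difference between the two cores is not broken down here. In this assay compound 3 reaches only a limit, > 64000 nM, one of the values sitting at the limit of > 64000 nM in this assay, at which 1 of the 3 values shown sits. Compound 4, `O=C(CNc1ccccc1)N[C@H]1CCOC1=O`, has not yet been measured; it differs from compound 3 by hydrogen in place of chloro on an aromatic carbon, the same kind of change as that from compound 1 to compound 2, though here the place is meta to a large group rather than meta to a chloro group and para to a large group. Compound 4 is expected to remain at or near the limit, an estimated step that the limit leaves unreadable from compound 3 to compound 4, because compound 3 gives > 64000 nM and the earlier step of a 2.7-fold lower number from compound 1 to compound 2 (0.42 log units; beyond the scatter) was modest. Compound 4 is therefore estimated at 80000 nM, between 25000 nM and 300000 nM.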

Compound 4, half-maximal inhibitory concentration: > 64000 nM
Compound 4: only a limit was reported; the forecaster's own chance of this, stated with the estimate: 75%; the middle value is on the limit's open side.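

Compound 3 and compound 4 both stand at a limit in this assay, so no step between them can be read: the limit of > 64000 nM in this assay, at which 2 of the 4 values shown sit.

The compounds shown leave open whether hydrogen in place of chloro changes anything on the core of compound 3.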